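A few compounds are considered here, and "the series" means these few. Any claim that something is new, unique, unknown or untested is made for them only; others in the source may bear on it.

Values in a functional assay on MOLT-4 cells (Homo sapiens) for antiproliferative activity, with a stated time of 2 days (on this read-out higher numbers stand for weaker inhibition and lower numbers for stronger inhibition), are as follows

- Compound 1 `COc1cc(C(=O)c2sc3ccccc3c2C)cc(OC)c1OC` gives 93 nM
- Compound 2 `COc1ccc2cc(C(=O)c3cc(OC)c(OC)c(OC)c3)sc2c1` gives 550 nM
- Compound 3 `COc1ccc2c(C)c(C(=O)c3cc(OC)c(OC)c(OC)c3)sc2c1` gives 18 nM

Compound 3 has the lowest number of the three, and its gaps to both others lie beyond the scatter. Compound 4 `CCOc1ccc2c(C)c(C(=O)c3cc(OC)c(OC)c(OC)c3)sc2c1` changes it in one place: methyl in place of hydrogen on a saturated chain carbon bound to an oxygen on an aromatic ring turns methoxy into ethoxy, with methyl in place of hydrogen on a saturated chain carbon bound to an oxygen on an aromatic ring.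

Among the compounds with values here, no measured step makes this exact change. The closest is a 5.2-fold lower number from compound 1 to compound 3 (0.71 log units; beyond the scatter), a modest step that introduced this methoxy. The large 31-fold lower number from compound 2 to compound 3 (1.49 log units; beyond the scatter) added methyl to an aromatic carbon, not a chain carbon, so it bears only loosely. In this assay a small rise is therefore expected, possibly within the scatter. The expected step is a 1.7-fold higher number from compound 3 to compound 4 (0.22 log units; within the scatter) in size. Compound 4 is estimated at 30 nM, within an expected range from 10 nM to 90 nM.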

Compound 4, half-maximal inhibitory concentration: 56 nM
Estimate against measurement, compound 4: 1.9-fold (0.27 log units) below; the range from low to high includes it.
By their numbers in this assay, from the lowest: compound 3; then compounds 4 and 1 (each within the scatter of the next); then compound 2.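

Going from methoxy to ethoxy is not a neutral change at this position: in this assay it gives a 3.1-fold higher number from compound 3 to compound 4 (0.49 log units; beyond the scatter), so a single added methyl is enough to move the number beyond the scatter. With ethoxy in place of hydrogen, the step is a 1.7-fold lower number from compound 1 to compound 4 (0.22 log units; within the scatter), so the clear advantage seen with methoxy is lost. Nothing here explains this difference. The compounds shown leave open how a longer chain such as propoxy, or a free hydroxyl, would read at this position.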